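This account rests on a few compounds, and the source may have more. Where it says the series, first, only, none or still open, it means among the compounds named here.

Values so far in a functional assay on T47D cells (Homo sapiens) for inhibition, read by sulforhodamine B assay, with a stated time of 48 h; on this read-out lower numbers stand for stronger inhibition of growth and higher numbers for weaker inhibition of growth:
- compound 1 `O=C(Nc1cccc(-n2cc(-c3ccncc3)c(-c3ccc(Cl)c(O)c3)n2)c1)Nc1cccc(C(F)(F)F)c1` gives > 32500 nM as a limit
- compound 2 `COc1cc(-c2nn(-c3cccc(NC(=O)Nc4ccc(Cl)c(Cl)c4)c3)cc2-c2ccncc2)ccc1Cl` gives > 50000 nM as a limit
- compound 3 `O=C(Nc1cccc(-n2cc(-c3ccncc3)c(-c3ccc(Cl)c(O)c3)n2)c1)Nc1ccc(Cl)c(Cl)c1` gives 17900 nM as a number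

Compound 2 has only the limit > 50000 nM and no number. Compound 4 `COc1cc(-c2nn(-c3cccc(NC(=O)c4ccc(Cl)c(C(F)(F)F)c4)c3)cc2-c2ccncc2)ccc1Cl` differs from it by 4-chloro-3-(trifluoromethyl)phenyl in place of (3,4-dichlorophenyl)amino on a carbonyl carbon in words, 4-chloro-3-(trifluoromethyl)phenyl in place of (3,4-dichlorophenyl)amino on a carbonyl carbon. The step of an at least 1.8-fold lower number from compound 1 to compound 3 (0.25 log units; that floor lies within the scatter) exchanges only the aryl group on an amide-type nitrogen. The step of an at least 2.7-fold lower number from compound 2 to compound 3 (0.44 log units; beyond the scatter) concerns a methyl on an oxygen, and compound 4 retains that methyl. Neither covers the exchange on the carbonyl carbon, so no shift beyond the scatter is expected, and the expected move is a number no higher from compound 2 to compound 4 (the limit leaves the size open) in this small set. For compound 4 the estimated value is 50000 nM with an expected range of 20000 nM to 100000 nM in this assay's terms. A report as a limit is likely.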

Compound 4, concentration for total growth inhibition: > 32500 nM
Compound 4 gave a limit, no number; the forecaster's own chance of this, stated with the estimate: 65%; the middle value lies beyond the limit too.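

In this assay, compound 2 and compound 4 are both reported only as limits, so the step between them cannot be read. Still open, on these data alone, is whether 4-chloro-3-(trifluoromethyl)phenyl in place of (3,4-dichlorophenyl)amino on a carbonyl carbon changes growth inhibition at all.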